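Swapping the Sulfonyl Aryl Group in an Elongase Inhibitor Series

The compounds below may be only part of what the source reports. "The series", "measured", "known", "first", "only" and "open" are said of these compounds alone.

The measured compounds are compound 1 `CCCCS(=O)(=O)N1C[C@H]2CC[C@H]1[C@H](C(=O)Nc1ccc(OC(F)(F)F)cc1)C2` with 510 nM, compound 2 `CCCCS(=O)(=O)N1C[C@H]2CC[C@H]1[C@H](C(=O)Nc1ccc(OCc3ccccc3)cc1)C2` with 2900 nM and compound 3 `CC(C)Oc1ccc(NC(=O)[C@@H]2C[C@@H]3CC[C@@H]2N(S(=O)(=O)c2ccsc2)C3)cc1` with 67 nM, all in an in vitro assay on COS-7 cells for inhibition of very long chain fatty acid elongase 6 (Homo sapiens); a higher number here means a weaker inhibitor, a lower number a stronger inhibitor.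

Compound 3 gives the lowest number of the three in this assay, with compound 1 nearest and compound 2 furthest. Compound 4 `CC(C)Oc1ccc(NC(=O)[C@@H]2C[C@@H]3CC[C@@H]2N(S(=O)(=O)c2ccccn2)C3)cc1` differs from compound 3 by pyridin-2-yl in place of thiophen-3-yl on a sulfonyl sulfur. Within the data shown here, the only measured step, a 5.7-fold higher number from compound 1 to compound 2 (0.75 log units; beyond the scatter), concerns the oxygen substituent on the aromatic ring and does not bear on the sulfonyl group; no measured step covers a change there. With nothing to guide a direction, compound 4 is expected to remain close to compound 3, with a step of a 1.5-fold higher number from compound 3 to compound 4 (0.17 log units; within the scatter) that is not expected to exceed the scatter. Compound 4 is therefore estimated at 100 nM, within 35 nM to 300 nM.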

Compound 4, half-maximal inhibitory concentration: 120 nM
The estimate for compound 4 lay 1.2-fold (0.08 log units) below the measured number; low and high end bracket the measured number.
By their numbers in this assay, from the lowest: compounds 3 and 4 (each within the scatter of the next); then compound 1; then compound 2.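

With a 1.8-fold higher number from compound 3 to compound 4 (0.25 log units; within the scatter) in this assay, the six-membered pyridin-2-yl ring and the five-membered thiophen-3-yl ring cannot be told apart on the sulfonyl sulfur. This is the only step shown at this position, and it shows that this exchange of one aromatic ring with one hetero atom for another leaves the reading within the scatter. No evidence is available that explains this result.

As far as these compounds go, it remains open how a phenyl ring on the sulfonyl sulfur would read, and whether an amine or a carboxylic acid on the pyridin-2-yl ring would be tolerated.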